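The source may report more compounds than this note shows. Statements on the series, on what has been measured and on what is new or still open speak of the compounds shown alone.

Measured compounds in a functional assay on CNE-2 cells (Homo sapiens) for cytotoxicity, read by MTT assay, with a stated time of 72 h; on this read-out lower numbers stand for stronger inhibition and higher numbers for weaker inhibition:
Compound 1 `COc1cc2ncnc(NNC(=S)NC(=O)c3ccccc3Cl)c2cc1OC` gives 9670 nM in this assay.
Compound 2 `COc1cc2ncnc(NNC(=S)NC(=O)c3cccc(Cl)c3)c2cc1OC` gives 7460 nM in this assay.

Within the data shown here, compound 2 has the lower of the two numbers, but its only neighbour is compound 1, and the single measured step, a 1.3-fold lower number from compound 1 to compound 2 (0.11 log units; within the scatter), lies within the scatter; the two compounds therefore cannot be set in any order on this read-out.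

Compound 3 `COc1cc2ncnc(NNC(=S)NC(=O)c3ccccc3C)c2cc1OC` has not yet been measured. It differs from compound 2 by 2-methylphenyl in place of 3-chlorophenyl on a carbonyl carbon. Among the measured compounds shown here, the one measured step that bears on this change is the exchange of one chlorophenyl for another, a 1.3-fold lower number from compound 1 to compound 2 (0.11 log units; within the scatter), which stayed within the scatter. For the measured compounds named here, with only that step to go on, the expected change a 1.1-fold higher number from compound 2 to compound 3 (0.06 log units; within the scatter) is none beyond the scatter. Compound 3 is accordingly estimated at 8500 nM, with a likely range from 4000 nM to 18000 nM.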

Compound 3, half-maximal inhibitory concentration: 10500 nM
Beside the measured number, compound 3's estimate is 1.2-fold (0.09 log units) below it; the measured number falls inside the stated range.
By their numbers in this assay, from the lowest: compounds 2, 1 and 3 (each within the scatter of the next).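

In this assay, methyl in place of chloro on an aromatic carbon gives a 1.1-fold higher number from compound 1 to compound 3 (0.04 log units; within the scatter), so this first change of the substituent itself, rather than of its place, also stays within the scatter. The step of 2-methylphenyl in place of 3-chlorophenyl on a carbonyl carbon, a 1.4-fold higher number from compound 2 to compound 3 (0.15 log units; within the scatter), does the same, and all three compounds therefore remain unordered on this read-out. No measurement at hand offers an explanation for this flat result.

The compounds shown leave open whether any group on this phenyl ring can move the number beyond the scatter, such as a methoxy, a nitro, an amine or a carboxylic acid. They also leave open what an unsubstituted phenyl or a saturated ring such as cyclohexyl would give on the carbonyl carbon.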